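Working notes: cytotoxicity of compounds 1 to 4

The source may report more compounds than this note shows. Statements on the series, on what has been measured and on what is new or still open speak of the compounds shown alone.

Measured so far:
Compound 1, `CCOC(=O)N1CCC(=NNC(=O)c2ccc(C)cc2)CC1`. In a functional assay on A549 cells (Homo sapiens) for cytotoxicity, read by MTT assay, with a stated time of 24 h (a higher number here means a weaker inhibitor, a lower number a stronger inhibitor), compound 1 gives > 400000 nM, which is a limit of the assay and not a number.
Compound 2, `CCOC(=O)N1CCC(=NNC(=O)c2ccc(C(F)(F)F)cc2)CC1`. In this assay compound 2 gives 37100000 nM.
Compound 3, `Cc1ccc(C(=O)NN=C2CC(c3ccccc3)NC(c3ccccc3)C2)cc1`. In this assay compound 3 gives > 400000 nM, again a limit of the assay and not a number.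

From compound 1 to compound 2 the change is trifluoromethyl in place of methyl on an aromatic carbon. The step that the limit leaves unreadable from compound 1 to compound 2 cannot be sized because the limit of > 400000 nM in this assay, at which 2 of the 3 values shown sit, covers the value of compound 1.

Compound 4, `O=C(NN=C1CC(c2ccccc2)NC(c2ccccc2)C1)c1ccc(C(F)(F)F)cc1`, has not been measured. It differs from compound 3 by trifluoromethyl in place of methyl on an aromatic carbon, the same change as from compound 1 to compound 2, with the place described in the same words. The difference between the core of compound 1 and the core of compound 3 is not broken down here.

Among the compounds with values here, the one measured pair gives no readable size for this change in this assay; compound 2 at 37100000 nM shows only a very weak inhibitor after it. For compound 4 the expected step is a step that the limit leaves unreadable from compound 3 to compound 4, an estimate resting on compound 3 sitting at the limit. Compound 4 is therefore expected at 1500000 nM, between 300000 nM and 40000000 nM, and most likely to be reported again as a limit rather than a number.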

Compound 4, half-maximal inhibitory concentration: > 400000 nM
Compound 4: a limit, no number; the forecaster's own chance of this, stated with the estimate: 70%; the middle value does not contradict the limit.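

In this assay compound 4 gives > 400000 nM, a limit of the assay and not a number, so no step from compound 3 to compound 4 can be read, since compound 3 also sits at a limit: the limit of > 400000 nM in this assay, at which 3 of the 4 values shown sit.

Left open is how large the change from methyl to trifluoromethyl is on either core, and whether the core of compound 1 and the core of compound 3 differ at all.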